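The compounds below may be only part of what the source reports. "The series", "measured", "known", "first", "only" and "open" are said of these compounds alone.

Measured compounds:
- compound 1, `COc1cc(Nc2nc3ccccc3nc2S(=O)(=O)c2ccc(C)cc2)cc(OC)c1`: 20 nM
- compound 2, `Cc1ccc(S(=O)(=O)c2nc3ccccc3nc2Nc2ccc(N)cc2)cc1`: 1220 nM
- compound 3, `Cc1ccc(S(=O)(=O)c2nc3ccccc3nc2Nc2ccc(Cl)cc2)cc1`: 17500 nM

These three share one core and differ only in the group carried on the ring nitrogen. In a functional assay on HL-60 cells (Homo sapiens) for cytotoxicity, read by MTT assay, with a stated time of 72 h (on this read-out higher numbers stand for weaker inhibition and lower numbers for stronger inhibition), compound 1 stands lowest of the three numbers. The step of a 61-fold higher number from compound 1 to compound 2 (1.79 log units; beyond the scatter) and the step of an 880-fold higher number from compound 1 to compound 3 (2.94 log units; beyond the scatter) both move far beyond the scatter, and the step of a 14-fold higher number from compound 2 to compound 3 (1.16 log units; beyond the scatter) shows that a change on that nitrogen-linked ring alone is enough to shift the read-out a great deal.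

Compound 4, `COc1cc(Nc2nc3ccccc3nc2S(=O)(=O)c2ccc(F)cc2)cc(OC)c1`, has not yet been measured. It differs from compound 1 in a different part of the molecule: fluoro in place of methyl on an aromatic carbon. For the measured compounds named here, none of the measured steps touches this ring; all three concern the group on the nitrogen, while the (4-methylphenyl)sulfonyl stays the same in every measured compound. Going by the values given here, no measured step therefore bears directly on this change, and the data give no sign of how the sulfonyl-bearing ring responds to substitution. The change swaps one heavy atom for one heavy atom, and the expected step in this assay is none beyond the scatter, with room for a modest move in either direction. Compound 4 is therefore estimated at 30 nM, in the range 8 nM to 120 nM. This estimate corresponds to an expected step of a 1.5-fold higher number from compound 1 to compound 4 (0.18 log units; within the scatter).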

Compound 4, half-maximal inhibitory concentration: 2360 nM
Compound 4: the middle estimate sits 79-fold (1.90 log units) below what was measured; the whole stated range lies below it.
By their numbers in this assay, from the lowest: compound 1; then compounds 2 and 4 (each within the scatter of the next); then compound 3.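

Compound 4 shows that the ring on the sulfonyl group is far from a silent part of the molecule. In this assay, with 3,5-dimethoxyphenyl kept on the nitrogen, exchanging methyl for fluoro on an aromatic carbon, para to a large group, gives a 120-fold higher number from compound 1 to compound 4 (2.07 log units; beyond the scatter), a large step from replacing just one heavy atom with another, and neither group counts any hydrogen-bond donor or acceptor. The earlier compounds showed large steps only on the nitrogen-linked ring, whereas this result shows that the (4-methylphenyl)sulfonyl part can move the read-out strongly too, and no measurement at hand explains why.

From the compounds shown here alone, with only methyl and fluoro compared at this position, it remains open whether methyl is unusually favourable or fluoro unusually poor, which an ethyl, a methoxy or a trifluoromethyl group in the same place could help to separate. Also open, going by these compounds, is whether the same exchange would give a step of similar size with 4-aminophenyl or 4-chlorophenyl on the nitrogen instead of 3,5-dimethoxyphenyl.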